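The compounds below may be only part of what the source reports. "The series", "measured", "known", "first", "only" and "open" are said of these compounds alone.

Series notes. Compound 3 `C=CCOc1ccc2c(=O)c(-c3ccc(O)cc3)coc2c1` carries an allyl on the ether oxygen of the shared core; in an assay (Cricetulus griseus) for inhibition of aldehyde dehydrogenase, mitochondrial (Homo sapiens) (a lower number here means a stronger inhibitor, a higher number a weaker inhibitor), compound 3 gives 180 nM. Compound 1 `CCOC(=O)COc1ccc2c(=O)c(-c3ccc(O)cc3)coc2c1` gives 130 nM in this assay, and compound 2 `CCOC(=O)CCCCOc1ccc2c(=O)c(-c3ccc(O)cc3)coc2c1` gives 240 nM; the three numbers sit within the usual scatter of one another, and compound 3 is not set apart from either neighbour. Compound 4 `CC(C)Oc1ccc2c(=O)c(-c3ccc(O)cc3)coc2c1` is the next member: isopropyl in place of allyl on an oxygen on an aromatic ring. Within the data shown here, the steps that bear on it all vary the group on this same oxygen: a 1.8-fold higher number from compound 1 to compound 2 (0.27 log units; within the scatter), a 1.4-fold higher number from compound 1 to compound 3 (0.14 log units; within the scatter) and a 1.3-fold lower number from compound 2 to compound 3 (0.12 log units; within the scatter). None of these moved the number beyond the scatter, and no step beyond the scatter is expected here either, a 1.1-fold higher number from compound 3 to compound 4 (0.05 log units; within the scatter). Compound 4 is therefore estimated at 200 nM, with a range of 90 nM to 450 nM.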

Compound 4, half-maximal inhibitory concentration: 80 nM
The estimate for compound 4 lay 2.5-fold (0.40 log units) above the measured number; the whole stated range lies above it.
By their numbers in this assay, from the lowest: compounds 4, 1, 3 and 2 (each within the scatter of the next, the first and the last beyond it).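

In this assay the group on this oxygen now moves the number beyond the scatter, with isopropyl in place of allyl giving a 2.3-fold lower number from compound 3 to compound 4 (0.35 log units; beyond the scatter) and isopropyl in place of 4-(ethoxycarbonyl)butyl giving a 3.0-fold lower number from compound 2 to compound 4 (0.48 log units; beyond the scatter). Against the (ethoxycarbonyl)methyl group the change stays within the scatter, at a 1.6-fold lower number from compound 1 to compound 4 (0.21 log units; within the scatter). Allyl and isopropyl both count 3 heavy atoms, so that count does not separate them, and nothing available accounts for the step. Still open, as far as these compounds go, is how a tert-butyl, a cyclopentyl or a free carboxylic acid on this oxygen would compare with isopropyl.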